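Swapping the pyridine arm of an oxime ether for a thiazole ester

The compounds below may be only part of what the source reports. "The series", "measured", "known", "first", "only" and "open" are said of these compounds alone.

Of the compounds shown here, three have been measured in a functional assay (blood) for inhibition, with Homo sapiens as the target; a lower number here means a stronger inhibitor, a higher number a weaker inhibitor. Compound 1 `COC1(c2cc(F)cc(Sc3ccc4c(c3)CC/C4=N\OCC#N)c2)CCOCC1` gives 30 nM, compound 2 `C/C(=N\OCc1ccncc1)c1ccc(Sc2cc(F)cc(C3CCOCC3)c2)cc1` gives 300 nM, and compound 3 `C/C(=N\O)c1cccc(Sc2cc(F)cc(C3CCOCC3)c2)c1` gives 2910 nM. Compound 2 therefore stands second highest of the three numbers: compound 1 sits well below it and compound 3 well above it, and both of those gaps lie beyond the usual scatter of repeated measurements. Compound 2 serves as the anchor for the compound that follows. Of compound 2 and compound 3 only the two values themselves can be set side by side.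

Compound 4 `CCOC(=O)c1csc(CO/N=C(\C)c2ccc(Sc3cc(F)cc(C4CCOCC4)c3)cc2)n1` has not yet been measured. It differs from compound 2 in one place: 4-(ethoxycarbonyl)-1,3-thiazol-2-yl in place of pyridin-4-yl on a saturated chain carbon bound to an oxygen. Among the measured compounds shown here, no measured pair shows this particular exchange, so the direction of the step is uncertain. A step roughly within the scatter, leaning slightly toward a lower number, is expected, as a 1.5-fold lower number from compound 2 to compound 4 (0.18 log units; within the scatter). Compound 4 is accordingly estimated at 200 nM, within a range from 60 nM to 700 nM.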

Compound 4, half-maximal inhibitory concentration: 150 nM
Compound 4: the middle estimate sits 1.3-fold (0.12 log units) above what was measured; low and high end bracket the measured number.
By their numbers in this assay, from the lowest: compound 1; then compounds 4 and 2 (each within the scatter of the next); then compound 3.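

Among the compounds shown here, this is the first pair in the set that differs in one place only, so the arm on the saturated chain carbon bound to an oxygen can now be judged on its own. In this assay, exchanging pyridin-4-yl for the larger 4-(ethoxycarbonyl)-1,3-thiazol-2-yl gives a 2.0-fold lower number from compound 2 to compound 4 (0.30 log units; within the scatter), so this position accepts a five-membered aromatic ring bearing an ester in place of a six-membered one with no change that can be told from the scatter. Nothing available accounts for this outcome.

The compounds shown leave open whether the thiazole ring or its ethoxycarbonyl group matters more at this position. A plain 1,3-thiazol-2-yl, or a carboxylic acid in place of the ethyl ester, would help separate the two parts.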